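Hydrogen for methyl on an aromatic nitrogen: cytotoxicity

A few compounds are considered here, and "the series" means these few. Any claim that something is new, unique, unknown or untested is made for them only; others in the source may bear on it.

Compound 1 `Cn1c(/C=C/C(=O)c2ccc[nH]2)cc(Br)c1Br`: in a functional assay on Caco-2 cells (Homo sapiens) for cytotoxicity, read by MTT assay, with stated times of 6 h and 48 h (on this read-out lower numbers stand for stronger inhibition and higher numbers for weaker inhibition), compound 1 gives >= 100000 nM, which is a limit of the assay, not a number.
Compound 2 `O=C(/C=C/c1cc(Br)c(Br)[nH]1)c1ccc[nH]1`: compound 2 gives >= 100000 nM, also a limit.
Compound 3 `Cn1c(-c2cc(-c3ccccc3O)no2)cc(Br)c1Br`: compound 3 gives >= 100000 nM, again a limit.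

All three values sit at the limit of >= 100000 nM in this assay, at which 3 of the 3 values shown sit. The change from compound 1 to compound 2 is hydrogen in place of methyl on an aromatic nitrogen, and the step that the two limits leave unreadable from compound 1 to compound 2 cannot be read because both ends sit at the limit of >= 100000 nM in this assay, at which 3 of the 3 values shown sit. Compound 4 `Oc1ccccc1-c1cc(-c2cc(Br)c(Br)[nH]2)on1` is not yet measured; it arises from compound 3 by hydrogen in place of methyl on an aromatic nitrogen, the same kind of change, differing in its surroundings only in that the large group stands where compound 1 carries the group of 9 heavy atoms. How the core of compound 1 and the core of compound 3 differ is not broken down here. Compound 4 is expected to show a step that the limit leaves unreadable from compound 3 to compound 4 in this assay, which rests on compound 3 sitting at the limit of >= 100000 nM in this assay, at which 3 of the 3 values shown sit, and on a step that the two limits leave unreadable from compound 1 to compound 2. Compound 4 is therefore estimated at 150000 nM, most likely once more a limit.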

Compound 4, half-maximal inhibitory concentration: >= 100000 nM
Compound 4 gave a limit, no number; the forecaster's own chance of this, stated with the estimate: 85%; the middle value is on the limit's open side.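

No size can be read for the change from compound 3 to compound 4, because both compounds sit at the same limit: the limit of >= 100000 nM in this assay, at which 4 of the 4 values shown sit.

Whether hydrogen in place of methyl on an aromatic nitrogen alters cytotoxicity at all remains open in the compounds shown.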